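A few compounds are considered here, and "the series" means these few. Any claim that something is new, unique, unknown or untested is made for them only; others in the source may bear on it.

Measured compounds:
Compound 1 `CN1C(=O)S/C(=C\C2=Cc3ccccc3OC2)C1=O`. In a functional assay on MOLT-4 cells (Homo sapiens) for antiproliferative activity, read by MTT assay, with a stated time of 72 h (on this read-out lower numbers stand for stronger inhibition and higher numbers for weaker inhibition), compound 1 gives > 100000 nM, which is a limit of the assay and not a number.
Compound 2 `CCN1C(=O)S/C(=C\C2=Cc3ccccc3OC2)C1=O`. In this assay compound 2 gives > 200000 nM, again a limit rather than a number.
Compound 3 `CC1Oc2ccc(Br)cc2C=C1/C=C1\SC(=O)N(C)C1=O`. In this assay compound 3 gives > 50000 nM, also a limit.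

All three measured values of this series sit at limits: the limit of > 100000 nM in this assay, at which 1 of the 3 values shown sits, the limit of > 200000 nM in this assay, at which 1 of the 3 values shown sits, and (the limit of > 50000 nM in this assay, at which 1 of the 3 values shown sits). Going by the values given here, no compound so far shows a readable number in this assay.

The change from compound 1 to compound 2 is methyl in place of hydrogen on a saturated chain carbon bound to an amide-type nitrogen in a ring. Its size is not readable: a step that the two limits leave unreadable from compound 1 to compound 2. Both ends are limits, so the step can be neither placed within nor beyond the usual scatter.

Compound 4 `CCN1C(=O)S/C(=C\C2=Cc3cc(Br)ccc3OC2C)C1=O` is not yet measured. It differs from compound 3 by methyl in place of hydrogen on a saturated chain carbon bound to an amide-type nitrogen in a ring, the same change as from compound 1 to compound 2, at the same place. How the core of compound 3 differs from the core of compound 1 is not broken down here.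

For compound 4 the expectation rests on compound 3 and its value > 50000 nM, a limit, and on the pair of limits for compound 1 and compound 2, where the same change left no readable effect. The step from compound 3 to compound 4 is therefore expected to be a step that the limit leaves unreadable from compound 3 to compound 4, with a limit again the most likely read-out. Compound 4 is estimated at 150000 nM in this assay, with a range from 40000 nM to 600000 nM.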

Compound 4, half-maximal inhibitory concentration: > 100000 nM
Compound 4 gave a limit, no number; the forecaster's own chance of this, stated with the estimate: 85%; the middle value lies beyond the limit too.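

In this assay compound 4 gives > 100000 nM, a limit of the assay and not a number. Compound 3 gives > 50000 nM, also a limit, so no step can be read between compound 3 and compound 4. The compounds shown leave open whether methyl in place of hydrogen at this place changes the antiproliferative read-out at all, as none of them yet gives a readable number.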